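From Hydrogen to Nitro on the Shared Core

The compounds below may be only part of what the source reports. "The series", "measured", "known", "first", "only" and "open" are said of these compounds alone.

For the measured compounds named here, the series rests on compound 1 `O=C1Nc2ccccc2/C1=N/NC(=S)N1CCN(c2ccccc2)CC1`, which in a functional assay on A549 cells (Homo sapiens) for inhibition, read by MTT assay, with a stated time of 72 h (a lower number here means a stronger inhibitor, a higher number a weaker inhibitor), gives 18600 nM, the second highest of the three numbers so far. Compound 2 `O=C1Nc2ccc(Cl)cc2/C1=N/NC(=S)N1CCN(c2ccccc2)CC1` gives 7340 nM in this assay, and compound 3 `O=C1Nc2ccc(F)cc2/C1=N/NC(=S)N1CCN(c2ccccc2)CC1` gives 20700 nM. The step of a 2.5-fold lower number from compound 1 to compound 2 (0.40 log units; beyond the scatter) shows that chloro in place of hydrogen at this position lowers the number, whereas a 1.1-fold higher number from compound 1 to compound 3 (0.05 log units; within the scatter) shows that fluoro in place of hydrogen changes nothing beyond the scatter; between the two halogens, a 2.8-fold higher number from compound 2 to compound 3 (0.45 log units; beyond the scatter).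

Compound 4 `O=C1Nc2ccc([N+](=O)[O-])cc2/C1=N/NC(=S)N1CCN(c2ccccc2)CC1` differs from compound 1 by nitro in place of hydrogen on an aromatic carbon. The same position carries the chloro of compound 2 and the fluoro of compound 3, so those two steps bear on it: one modest lowering, one within the scatter. Going by the values given here, no measured compound carries a group with two hydrogen-bond acceptors or one of three heavy atoms at this place, so the nearest guide is the chloro step. For compound 4 a modest lower number is expected, a 2.1-fold lower number from compound 1 to compound 4 (0.32 log units; beyond the scatter), giving an estimate of 9000 nM with a range from 3500 nM to 25000 nM.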

Compound 4, half-maximal inhibitory concentration: 17900 nM
The estimate for compound 4 lay 2.0-fold (0.30 log units) below the measured number; measured number inside the range.
By their numbers in this assay, from the lowest: compound 2; then compounds 4, 1 and 3 (each within the scatter of the next).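

In this assay nitro on this aromatic carbon does not follow chloro: the data show a 1.0-fold lower number from compound 1 to compound 4 (0.02 log units; within the scatter) and a 1.2-fold lower number from compound 3 to compound 4 (0.06 log units; within the scatter) but also a 2.4-fold higher number from compound 2 to compound 4 (0.39 log units; beyond the scatter) for the comparison with the chloro compound. Among the three groups shown here, chloro alone therefore stands apart from hydrogen beyond the scatter, while fluoro and nitro do not, so the three heavy atoms and two hydrogen-bond acceptors of nitro do not by themselves repeat the chloro step. Nothing available accounts for this difference between chloro and nitro.

Going by these compounds, whether the chloro step is particular to chloro or is shared by bromo, methyl, methoxy or an amine on the same carbon remains open. On these data alone, it is also open whether these groups would behave alike elsewhere on the shared core.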